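Swapping the Ring on the Sulfonyl Sulfur

This account rests on a few compounds, and the source may have more. Where it says the series, first, only, none or still open, it means among the compounds named here.

Of the compounds shown here, three sharing one core have been measured in a functional assay on the whole organism (6C3HED cells, Mus musculus) for inhibition, at a dose of 300 mg/kg by the oral route; on this read-out higher numbers stand for more inhibition at the one dose given (going by the name of the read-out) and lower numbers for less inhibition. Compound 1 `O=C(Nc1ccc(Cl)cc1)NS(=O)(=O)c1ccc(Cl)s1` gives 89%. Compound 2 `CCOc1ccc(S(=O)(=O)NC(=O)Nc2ccc(Cl)cc2)s1` gives 96%, and compound 3 `CCCc1ccc(S(=O)(=O)NC(=O)Nc2ccc(Cl)cc2)s1` gives 39%. Compound 1 thus stands second highest of the three: the step of a number 7 percentage points higher from compound 1 to compound 2 (within the scatter) lies within the scatter, while the step of a number 50 percentage points lower from compound 1 to compound 3 (beyond the scatter) is a large fall. The step of a number 57 percentage points lower from compound 2 to compound 3 (beyond the scatter) is of the same kind.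

Compound 4 `CCc1ccc(S(=O)(=O)NC(=O)Nc2ccc(Cl)cc2)[nH]1` has not been measured. Compared with compound 1, it carries 5-ethyl-1H-pyrrol-2-yl in place of 5-chlorothiophen-2-yl on a sulfonyl sulfur. Two things change at once: a chlorine on the ring gives way to an ethyl chain, and the ring itself is exchanged.

Only part of this is covered by the measured steps. The exchange of chloro for an alkyl chain has a precedent in the step of a number 50 percentage points lower from compound 1 to compound 3 (beyond the scatter), which was a large fall, and the step of a number 7 percentage points higher from compound 1 to compound 2 (within the scatter) shows that not every replacement of chloro costs inhibition. For the measured compounds named here, the exchange of the ring has no precedent here.

Because of the fall seen in a number 50 percentage points lower from compound 1 to compound 3 (beyond the scatter), a drop beyond the scatter is expected, of about a number 39 percentage points lower from compound 1 to compound 4 (beyond the scatter). Compound 4 is therefore estimated at 50%, between 20% and 85%.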

Compound 4, a percentage reported as inhibition, in the whole organism at one dose (the size of the read-out at that dose, not a potency): 56%
The estimate for compound 4 lay 6 percentage points below the measured number, and the stated range covers the measured number.
By their numbers in this assay, from the lowest: compound 3; then compound 4; then compounds 1 and 2 (each within the scatter of the next).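

Putting 5-ethyl-1H-pyrrol-2-yl in place of 5-chlorothiophen-2-yl on the sulfonyl sulfur gives, in this assay, a number 33 percentage points lower from compound 1 to compound 4 (beyond the scatter) and is thus a large fall. The new ring differs from the old one in its hetero atom and brings a hydrogen-bond donor that 5-chlorothiophen-2-yl lacks, yet compound 4 still gives 56% at the one dose tested, so this position accepts a change of the whole ring without losing all inhibition. The ring and the group on it change together in this single step, so the fall cannot be divided between them, and no measurement at hand offers an explanation for it.

Still open, from the compounds shown here alone, is how much of the fall belongs to the ring and how much to the ethyl group, a question that 5-chloro-1H-pyrrol-2-yl or 5-ethylthiophen-2-yl on the same sulfur could help to settle. Also open, going by these compounds, is how the pyrrole ring would behave with an ethoxy group, an amine or a carboxylic acid in the place of the ethyl group.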